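Swapping the phenyl for thiophene in a fused pyridine core

The source may hold more compounds than are shown below. What is called first, only, known or untested is meant among the compounds shown, and "the series" means these compounds.

Measured so far in a functional assay on Ehrlich cells (Mus musculus) for cytotoxicity, read by trypan blue exclusion, with a stated time of 2 h, tested at 50 ug/mL; a higher number here means a stronger effect of the compound at the concentration tested, a lower number a weaker effect:
- compound 1 `N#CC1=C(N)N(c2ccc(S(N)(=O)=O)cc2)C2=C(CCCC2)C1c1ccccc1` gives 20%
- compound 2 `N#CC1=C(N)N(c2ccc(S(N)(=O)=O)cc2)C2=C(CCCC2)C1c1ccc(O)cc1` gives 60%
- compound 3 `N#CC1=C(N)N(c2ccc(S(N)(=O)=O)cc2)C2=C(CCCC2)C1c1cccc([N+](=O)[O-])c1` gives 2%

Among these three, compound 1 stands second highest; compound 3 lies below it, and compound 2 lies well above it. Both of its neighbours differ from compound 1 only in the ring attached to the saturated ring carbon: a number 40 percentage points higher from compound 1 to compound 2 (beyond the scatter), while a number 18 percentage points lower from compound 1 to compound 3 (beyond the scatter). Between those two, a number 58 percentage points lower from compound 2 to compound 3 (beyond the scatter).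

Compound 4 `N#CC1=C(N)N(c2ccc(S(N)(=O)=O)cc2)C2=C(CCCC2)C1c1cccs1` differs from compound 1 in the same place, but in a different way: thiophen-2-yl in place of phenyl on a saturated ring carbon. For the measured compounds named here, no measured step exchanges the whole ring; the two known steps only add a group to the phenyl, and they pull in opposite directions, one large upward and one modest downward. Going by the values given here, a ring swap without any added hydroxy or nitro therefore has no direct precedent here, and the safest expectation is a step of uncertain direction and probably modest size, a number 2 percentage points higher from compound 1 to compound 4 (within the scatter), with a wide range to cover either way.

Compound 4 is thus estimated at 22% in this assay, within 5% to 45%.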

Compound 4, a percentage reported as activity, at one concentration (the size of the read-out at that concentration, not a potency): 10%
Compound 4: the middle estimate sits 12 percentage points above what was measured; the measured number falls inside the stated range.
By their numbers in this assay, from the lowest: compounds 3, 4 and 1 (each within the scatter of the next, the first and the last beyond it); then compound 2.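

Exchanging the whole ring on the saturated ring carbon, rather than adding a group to the phenyl, gives in this assay a number 10 percentage points lower from compound 1 to compound 4 (within the scatter) and so does not separate thiophen-2-yl from phenyl at this position. The same holds against the ring that carries the nitro group, with a number 8 percentage points higher from compound 3 to compound 4 (within the scatter), whereas the ring that carries the hydroxy stays clearly apart, with a number 50 percentage points lower from compound 2 to compound 4 (beyond the scatter), so a five-membered ring with sulfur does not by itself bring the high reading of compound 2 at this position. Nothing available here gives a reason for these differences between the rings.

Still open, from the compounds shown here alone, is whether the high reading of compound 2 needs the hydroxy itself, a question that a methoxy group, an amine or a carboxylic acid in its place on the phenyl could help to settle. Also open, going by these compounds, is how other rings would compare on the same carbon, such as thiophen-3-yl, furan-2-yl or pyridine, and whether a hydroxy on the thiophen-2-yl ring would raise the reading as it does on the phenyl.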